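The compounds below may be only part of what the source reports. "The series", "measured", "known", "first", "only" and "open" are said of these compounds alone.

Measured in a functional assay on DU-145 cells (Homo sapiens) for cytotoxicity, read by MTT assay, with a stated time of 48 h; on this read-out lower numbers stand for stronger inhibition and higher numbers for weaker inhibition:
- compound 1 `COc1cc(COCc2cn(Cc3cc(C)cnc3Cl)nn2)cc(OC)c1OC`: 34800 nM
- compound 2 `COc1cc(COCc2cn(Cc3cc(-c4ccc(C)cc4)cnc3Cl)nn2)cc(OC)c1OC`: 37000 nM

Among the measured compounds shown here, only these two compounds have numbers so far, and compound 2 stands level with compound 1, within the scatter of repeated measurements. Compound 3 `COc1cc(COCc2cn(Cc3cc(-c4ccccc4)cnc3Cl)nn2)cc(OC)c1OC` has not yet been measured. It differs from compound 2 by a single small edit: hydrogen in place of methyl on an aromatic carbon. Put simply, this is hydrogen in place of methyl on an aromatic carbon, which turns 4-methylphenyl into phenyl.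

For the measured compounds named here, one measured step bears on this edit. Placing 4-methylphenyl where compound 1 carries methyl gave a 1.1-fold higher number from compound 1 to compound 2 (0.03 log units; within the scatter). That swap brought in a much larger group, yet the number did not move beyond the scatter. Removing one methyl from that group is a smaller edit, so no step beyond the scatter is expected in this assay, in either direction. Going by the values given here, with only one step to go on, this expectation remains loose. The estimated step is a 1.1-fold lower number from compound 2 to compound 3 (0.02 log units; within the scatter). For compound 3 the expected value is 35000 nM, with an estimated range from 18000 nM to 65000 nM.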

Compound 3, half-maximal inhibitory concentration: 45500 nM
Beside the measured number, compound 3's estimate is 1.3-fold (0.11 log units) below it; measured number inside the range.
By their numbers in this assay, from the lowest: compounds 1, 2 and 3 (each within the scatter of the next).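

In this assay, removing the methyl from the 4-methylphenyl group gives a 1.2-fold higher number from compound 2 to compound 3 (0.09 log units; within the scatter), so this small edit leaves the number level. Comparing plain phenyl with the methyl of the simplest compound gives a 1.3-fold higher number from compound 1 to compound 3 (0.12 log units; within the scatter), which adds a second large-group comparison to the earlier one and again shows no separation. Methyl, phenyl and 4-methylphenyl at this position therefore cannot be told apart on this read-out, and all three compounds stand together, with no order among them. No measurement that could account for this level result is at hand.

The compounds shown leave open whether an amine or a carboxylic acid on the phenyl ring, or a longer chain such as butyl in place of the methyl of compound 1, would move the number beyond the scatter. As far as these compounds go, all three share the same carbon-and-hydrogen character at this position, so it also remains open whether any group carrying nitrogen or oxygen here would separate from them in this assay at all.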